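The compounds below may be only part of what the source reports. "The series", "measured", "known", "first", "only" and "open" are said of these compounds alone.

Among the compounds with values here, compound 2 `Nc1scc(CN2CCN(c3ccncc3)CC2)c1C(=O)c1ccc(Cl)cc1` gives -8.3% in a functional assay on CHO cells with adenosine receptor A1 (Homo sapiens) as the target, read by cAMP accumulation and immunoassay, with a stated time of 6 min, tested at 1 uM (a lower number here means a stronger effect, a higher number a weaker effect of the compound at the concentration tested), the higher of the two numbers measured so far. Compound 1 `Nc1scc(CN2CCN(c3cccc(C(F)(F)F)c3)CC2)c1C(=O)c1ccc(Cl)cc1` gives -72% in this assay, so the step of a number 63.7 percentage points higher from compound 1 to compound 2 (beyond the scatter) is the only measured one, and it shows that the group on the ring nitrogen can move the read-out a long way. Compound 3 `Nc1scc(CN2CCN(C3CCCCCC3)CC2)c1C(=O)c1ccc(Cl)cc1` differs from compound 2 by cycloheptyl in place of pyridin-4-yl on an amine nitrogen in a ring. Within the data shown here, no measured step exchanges an aromatic group for a saturated ring at this place, so the single known step offers no direct guide to the direction of the new one. Compound 3 is therefore expected to land somewhere between the two measured numbers, a step of a number 31.7 percentage points lower from compound 2 to compound 3 (beyond the scatter) in this assay, because the step of a number 63.7 percentage points higher from compound 1 to compound 2 (beyond the scatter) shows this position to be sensitive. Compound 3 is estimated at -40%, with a range from -80% to 0%.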

Compound 3, a percentage reported as activity, at one concentration (the size of the read-out at that concentration, not a potency): 3.7%
Beside the measured number, compound 3's estimate is 43.7 percentage points below it; the measured number lies above the stated range.
By their numbers in this assay, from the lowest: compound 1; then compound 2; then compound 3.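

In this assay, the saturated all-carbon cycloheptyl ring on an amine nitrogen in a ring moves the read-out the same way as pyridin-4-yl, only further, with a number 12 percentage points higher from compound 2 to compound 3 (beyond the scatter) and a number 75.7 percentage points higher from compound 1 to compound 3 (beyond the scatter). Among these three compounds, then, the low number belongs to the 3-(trifluoromethyl)phenyl group alone, while two very different rings, one aromatic with a nitrogen and one saturated with carbon only, both leave the number far higher. No evidence here explains why the numbers fall this way.

As far as these compounds go, it remains open whether the low number of compound 1 rests on its phenyl ring or on its trifluoromethyl group, which a plain phenyl group would help to separate. From the compounds shown here alone, how a smaller saturated ring such as cyclopentyl or an open butyl chain would read at this place also remains open.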